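A furan-3-yl group replaces 4-methoxybenzyl

The source may hold more compounds than are shown below. What is called first, only, known or untested is meant among the compounds shown, and "the series" means these compounds.

Compound 1 `CCOC(=O)c1ccc(-c2nn(Cc3ccc(Cl)cc3)c3ccccc23)cc1`: > 10000 nM (a limit)
Compound 2 `CCOC(=O)c1ccc(-c2nn(Cc3ccc(OC)cc3)c3ccccc23)cc1`: > 10000 nM (a limit)

In a functional assay on cells (Platelet, Homo sapiens) for inhibition (a lower number here means a stronger inhibitor, a higher number a weaker inhibitor), compound 2 stands at > 10000 nM, which is a limit and not a number. Both measured compounds rest on (the limit of > 10000 nM in this assay, at which 2 of the 2 values shown sit). Compound 3 `CCOC(=O)c1ccc(-c2nn(-c3ccoc3)c3ccccc23)cc1` differs from compound 2 by furan-3-yl in place of 4-methoxybenzyl on an aromatic nitrogen. For the measured compounds named here, the only measured step is a step that the two limits leave unreadable from compound 1 to compound 2, so it offers no size to carry over, and it lies at a different place. No clear step in this assay is therefore expected, in either direction. The expected change is a step that the limit leaves unreadable from compound 2 to compound 3. For compound 3 the estimate is 15000 nM, with an expected range of 5000 nM to 50000 nM.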

Compound 3, half-maximal inhibitory concentration: > 10000 nM
Compound 3 was reported as a limit; the forecaster's own chance of this, stated with the estimate: 80%; the middle value is on the limit's open side.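

The results for compound 1, compound 2 and compound 3 are all limits and not numbers, so no step among them can be read: the limit of > 10000 nM in this assay, at which 3 of the 3 values shown sit.

The compounds shown leave open how strongly any of the three inhibits, and whether the group on the aromatic nitrogen changes that.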